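Pyridin-2-yl for pyrimidin-5-yl on the amide nitrogen

This account rests on a few compounds, and the source may have more. Where it says the series, first, only, none or still open, it means among the compounds named here.

Measured compounds:
compound 1 `CC(C)n1ncc2c(C(=O)Nc3ccccn3)cc(-c3ccsc3)nc21` — 25000 nM
compound 2 `CC(C)n1ncc2c(C(=O)Nc3ccc(F)c(F)c3)cc(-c3cccs3)nc21` — > 200000 nM
compound 3 `CC(C)n1ncc2c(C(=O)Nc3cncnc3)cc(-c3cccs3)nc21` — 20000 nM

In an ADME assay on LLC-MK2 cells (Macaca mulatta) for cytotoxicity, read by spectrophotometry and crystal violet staining, with a stated time of 4 days (on this read-out higher numbers stand for lower toxicity in this test and lower numbers for higher toxicity in this test), compound 3 gives 20000 nM, the lowest of the two numbers recorded; compound 1 gives 25000 nM, within the scatter of compound 3. The value of compound 2 in this assay is a limit, (the limit of > 200000 nM in this assay, at which 1 of the 3 values shown sits), not a number.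

Compound 4 `CC(C)n1ncc2c(C(=O)Nc3ccccn3)cc(-c3cccs3)nc21` differs from compound 3 in one place: pyridin-2-yl in place of pyrimidin-5-yl on an amide-type nitrogen. Among the measured compounds shown here, the only measured step touching the same position is an at least 10-fold lower number from compound 2 to compound 3 (1.00 log units; beyond the scatter), which starts from a limit and replaces 3,4-difluorophenyl rather than a pyridin-2-yl group, so it bears on the new change only loosely. Compound 1 carries the same pyridin-2-yl on an amide-type nitrogen and differs from compound 4 elsewhere; its number sits within the scatter of compound 3. No step beyond the scatter is therefore expected, and the estimate means a 1.3-fold higher number from compound 3 to compound 4 (0.10 log units; within the scatter). Compound 4 is expected to give about 25000 nM in this assay, between 10000 nM and 60000 nM.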

Compound 4, half-maximal cytotoxic concentration: > 200000 nM
Compound 4 was reported as a limit; the forecaster's own chance of this, stated with the estimate: 5%; middle value at least 8.0-fold (0.90 log units) from the limit.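

In this assay, the group on the amide-type nitrogen matters even with thiophen-2-yl held constant: pyridin-2-yl in place of pyrimidin-5-yl gives an at least 10-fold higher number from compound 3 to compound 4 (1.00 log units; beyond the scatter). Compound 1 had suggested that pyridin-2-yl was compatible with a low number, but with pyridin-2-yl held constant, thiophen-2-yl in place of thiophen-3-yl gives an at least 8.0-fold higher number from compound 1 to compound 4 (0.90 log units; beyond the scatter), so the low number of compound 1 cannot be credited to the amide substituent alone. Compound 2 and compound 4 are both reported as limits, so the step from one to the other cannot be read: the limit of > 200000 nM in this assay, at which 2 of the 4 values shown sit.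

The compounds shown do not explain why either change moves the number so far, nor how far the true values of compound 2 and compound 4 lie past the limit. They also leave open whether pyridin-3-yl or a simple methyl group on the amide-type nitrogen would give a low number or a limit.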